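A few compounds are considered here, and "the series" means these few. Any claim that something is new, unique, unknown or untested is made for them only; others in the source may bear on it.

Measured in a functional assay on MDA-MB-231 cells (Homo sapiens) for cytotoxicity; on this read-out lower numbers stand for stronger inhibition of growth and higher numbers for weaker inhibition of growth:
Compound 1, `OCC#Cc1ccccc1C#Cc1ccccc1`: 3260 nM
Compound 2, `OCCC#Cc1ccccc1C#Cc1ccccc1`: 3410 nM

Within the data shown here, compound 2 stands beside compound 1, the only other measured compound, the pair separated by a 1.0-fold higher number from compound 1 to compound 2 (0.02 log units; within the scatter). Compound 3, `OCCCCC#Cc1ccccc1C#Cc1ccccc1`, carries 2-hydroxyethyl in place of hydroxy on a saturated chain carbon, two bonds along the chain from a triple-bonded carbon. Among the measured compounds shown here, the one step that bears on this change is the chain extension already seen, a 1.0-fold higher number from compound 1 to compound 2 (0.02 log units; within the scatter), which stayed within the scatter; the change to compound 3 is of the same kind, a further lengthening of the same chain, so no step beyond the scatter is expected in this assay. Compound 3 is therefore estimated at 3500 nM, within 1700 nM to 7200 nM, an expected step of a 1.0-fold higher number from compound 2 to compound 3 (0.01 log units; within the scatter).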

Compound 3, concentration for 50% growth inhibition: 4290 nM
Beside the measured number, compound 3's estimate is 1.2-fold (0.09 log units) below it, within the range that was stated.
By their numbers in this assay, from the lowest: compounds 1, 2 and 3 (each within the scatter of the next).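

In this assay, 2-hydroxyethyl in place of hydroxy, two bonds along the chain from a triple-bonded carbon, gives a 1.3-fold higher number from compound 2 to compound 3 (0.10 log units; within the scatter) and does not take the value outside the scatter. Read against the shortest chain, the 3-hydroxypropyl change gives a 1.3-fold higher number from compound 1 to compound 3 (0.12 log units; within the scatter) and also stays within the scatter, so this larger change shows no step either. Nothing shown offers an explanation for this. Still open, going by these compounds, is whether an amine or a carboxylic acid in place of the hydroxy, or a chain longer than 6-hydroxyhex-1-yn-1-yl, would give a step beyond the scatter.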